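From Fluoro to Methoxy on the Shared Core

The compounds below may be only part of what the source reports. "The series", "measured", "known", "first", "only" and "open" are said of these compounds alone.

Compound 3 `Fc1ccc(C2=NN(C3=NC(c4ccccc4)CS3)C(c3ccc4ccccc4c3)C2)cc1` gives 9730 nM in a functional assay on HeLa cells (Homo sapiens) for inhibition, read by CCK-8 assay, with a stated time of 48 h (a higher number here means a weaker inhibitor, a lower number a stronger inhibitor), the second highest of the three numbers measured. Compound 2 `Fc1ccc(C2=NN(C3=NC(c4ccccc4)CS3)C(c3cccc4ccccc34)C2)cc1` gives 12400 nM, and a 1.3-fold lower number from compound 2 to compound 3 (0.11 log units; within the scatter). Compound 1 `Cc1ccc(C2=NN(C3=NC(c4ccccc4)CS3)C(c3ccc4ccccc4c3)C2)cc1` gives 2460 nM, and a 4.0-fold higher number from compound 1 to compound 3 (0.60 log units; beyond the scatter). Compound 4 `COc1ccc(C2=NN(C3=NC(c4ccccc4)CS3)C(c3ccc4ccccc4c3)C2)cc1` differs from compound 3 by methoxy in place of fluoro on an aromatic carbon. Among the compounds with values here, only the step from compound 1 to compound 3 touches this position, and there the exchange of methyl for fluoro raised the number by a modest margin; no measured step involves methoxy. For compound 4 a lower number than that of compound 3 is therefore expected, with wide uncertainty, as a 2.4-fold lower number from compound 3 to compound 4 (0.39 log units; beyond the scatter). Compound 4 is estimated at 4000 nM, with a range from 1500 nM to 12000 nM.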

Compound 4, half-maximal inhibitory concentration: 1860 nM
The estimate for compound 4 lay 2.2-fold (0.33 log units) above the measured number, and the stated range covers the measured number.
By their numbers in this assay, from the lowest: compounds 4 and 1 (each within the scatter of the next); then compounds 3 and 2 (each within the scatter of the next).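

In this assay, the 4-methoxyphenyl group shows that this position can carry a group other than methyl and still give a low number: the change from 4-fluorophenyl to 4-methoxyphenyl gives a 5.2-fold lower number from compound 3 to compound 4 (0.72 log units; beyond the scatter) and is the larger of the two steps at this position. Methoxy and methyl do not separate, with a 1.3-fold lower number from compound 1 to compound 4 (0.12 log units; within the scatter) and so fluoro alone stands apart among the three groups. Going by these compounds, whether an amine, a hydroxyl or an ethoxy group at this position would match methoxy and methyl remains open. No measurement shown explains the difference between these groups.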